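The source may hold more compounds than are shown below. What is called first, only, known or untested is meant among the compounds shown, and "the series" means these compounds.

Measured compounds:
- compound 1, `CC(=O)OCc1ccc2oc(=O)c(C(=O)Sc3ccccc3)cc2c1`: 89.5%
- compound 2, `CC(=O)OCc1ccc2oc(=O)c(C(=O)Sc3cccc(Br)c3)cc2c1`: 79.6%
- compound 3, `CCC(=O)OCc1ccc2oc(=O)c(C(=O)Oc3cccc(Br)c3)cc2c1`: 84.4%

In a functional assay on HT-1080 cells (Homo sapiens), read by transwell migration, with a stated time of 24 h, tested at 0.1 uM (a higher number here means a weaker effect of the compound at the concentration tested, a lower number a stronger effect), the three values of compound 1, compound 2 and compound 3 all lie within the usual scatter of one another, so none can be ranked against the others. Compound 3 gives 84.4%, and its gaps to the values of compound 1 and compound 2 are both inside the scatter. Among the compounds with values here, the only single-point step so far, a number 9.9 percentage points lower from compound 1 to compound 2 (within the scatter), is also within the scatter and concerns the bromo substituent, not the ester chain.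

Compound 4, `CCCCCC(=O)OCc1ccc2oc(=O)c(C(=O)Oc3cccc(Br)c3)cc2c1`, differs from compound 3 by propyl in place of hydrogen on a saturated chain carbon, two bonds along the chain from a carbonyl carbon. Within the data shown here, no measured pair in the set bears on a change of this kind; the ester chain varies only between compound 2 and compound 3, and that pair differs in two places, so its values show only that both sit within the scatter of each other.

With nothing in the data pointing to a step beyond the scatter, the expectation is that the step of a number 0.4 percentage points lower from compound 3 to compound 4 (within the scatter) stays within the scatter. In this assay compound 4 is therefore estimated at 84%, with a range from 70% to 96%.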

Compound 4, a percentage reported as activity, at one concentration (the size of the read-out at that concentration, not a potency): 94.3%
For compound 4 the middle estimate is 10.3 percentage points below the measured one; the range from low to high includes it.
By their numbers in this assay, from the lowest: compounds 2, 3, 1 and 4 (each within the scatter of the next, the first and the last beyond it).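

In this assay, within the data shown here, the ester chain is varied in one place only for the first time, and the step, a number 9.9 percentage points higher from compound 3 to compound 4 (within the scatter), is the first direct reading of this position. Propyl in place of hydrogen on a saturated chain carbon, two bonds along the chain from a carbonyl carbon, therefore gives a step that cannot be told apart from repeat scatter, so this single-concentration read-out does not separate the propanoyl ester from the pentylcarbonyl ester and says nothing about potency. No measurement available here bears on this result.

Still open, going by these compounds, is whether a chain longer than pentylcarbonyl, or a chain ending in an amine or a carboxylic acid, would give a step beyond the scatter at this position. Also open, on these data alone, is whether the same propyl change would give a comparable step on compound 2, whose linking atom is sulfur where compound 3 has oxygen and whose ester is an acetate rather than a propanoate.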